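Chloro for Hydroxy on the Pendant Ring of Compound 2

This account rests on a few compounds, and the source may have more. Where it says the series, first, only, none or still open, it means among the compounds named here.

Compound 2 `N#CC1=C(N)N(c2ccc(S(N)(=O)=O)cc2)C2=C(CCCC2)C1c1ccccc1O` stands lowest of the three measured compounds in a functional assay on Ehrlich cells (Mus musculus) for cytotoxicity, read by trypan blue exclusion, with a stated time of 2 h, tested at 10 ug/mL (a higher number here means a stronger effect of the compound at the concentration tested, a lower number a weaker effect), where compound 2 gives 10%. Its nearest neighbour is compound 1 `Cc1ccc(C2C(C#N)=C(N)N(c3ccc(S(N)(=O)=O)cc3)C3=C2CCCC3)cc1`, which in this assay gives 20%, the step being a number 10 percentage points lower from compound 1 to compound 2 (within the scatter). Compound 3 `N#CC1=C(N)N(c2ccc(S(N)(=O)=O)cc2)C2=C(CCCC2)C1c1ccc(O)cc1` gives 20%, and the step of a number 10 percentage points higher from compound 2 to compound 3 (within the scatter) is likewise within the scatter, as is no change at the digits printed from compound 1 to compound 3 (within the scatter).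

Compound 4 `N#CC1=C(N)N(c2ccc(S(N)(=O)=O)cc2)C2=C(CCCC2)C1c1ccccc1Cl` differs from compound 2 by chloro in place of hydroxy on an aromatic carbon. Two measured steps alter the same pendant ring on the saturated ring carbon, and one alters a substituent on an aromatic carbon; all three lie within the scatter, so the data give no sign that this position moves the read-out. Among the measured compounds shown here, no step exchanges hydroxy for chloro, so the expectation rests only on that quiet. The step of a number 5 percentage points higher from compound 2 to compound 4 (within the scatter) is therefore expected to stay within the scatter. Compound 4 is estimated to give 15%, within a range from 5% to 35%.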

Compound 4, a percentage reported as activity, at one concentration (the size of the read-out at that concentration, not a potency): 0%
Beside the measured number, compound 4's estimate is 15 percentage points above it; the whole stated range lies above it.
By their numbers in this assay, from the lowest: compounds 4, 2, 1 and 3 (each within the scatter of the next, the first and the last beyond it).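

In this assay, chloro in place of hydroxy on the pendant ring gives a step that stays inside the noise (a number 10 percentage points lower from compound 2 to compound 4 (within the scatter)), so this exchange at this place, taken alone, shows no clear effect. The 2-chlorophenyl compound nevertheless brings the only steps beyond the scatter among the compounds shown (a number 20 percentage points lower from compound 3 to compound 4 (beyond the scatter); a number 20 percentage points lower from compound 1 to compound 4 (beyond the scatter)), both modest, and each exchanges the whole substituted pendant ring rather than a single group on it. Nothing available here gives a reason for these steps.

The compounds shown leave open whether an amine or a methoxy group in place of the chloro would read like hydroxy or like chloro. They also leave open whether any group on this pendant ring can lift the read-out clearly above the small values seen so far.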